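The source may hold more compounds than are shown below. What is called first, only, known or untested is meant among the compounds shown, and "the series" means these compounds.

In a functional assay on the whole organism with Rattus norvegicus as the target (on this read-out lower numbers stand for an effect already at smaller amounts and higher numbers for an effect only at larger amounts of compound), compound 1 `CCCCOc1ccc(-c2c(C)[nH]c(=O)n2C)cc1` gives 0.3 mg/kg, the lower of the two numbers measured. Among the measured compounds shown here, compound 2 `Cc1[nH]c(=O)n(C)c1-c1ccc(CC(C)C)cc1` gives 30 mg/kg, and the only measured step, a 100-fold higher number from compound 1 to compound 2 (2.00 log units; beyond the scatter), shows how much one change at this aromatic carbon can shift the read-out. Compound 3 `CCCCCCCCOc1ccc(-c2c(C)[nH]c(=O)n2C)cc1` differs from compound 1 by butyl in place of hydrogen on a saturated chain carbon, four bonds along the chain from an oxygen on an aromatic ring. For the measured compounds named here, no measured step lengthens this chain, so the step from compound 1 to compound 2 bears only loosely on it, and a change smaller than that one is expected, if any beyond the scatter. Compound 3 is therefore estimated to lie near 1 mg/kg, within 0.1 mg/kg to 10 mg/kg, an expected step of a 3.3-fold higher number from compound 1 to compound 3 (0.52 log units; beyond the scatter).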

Compound 3, minimum effective dose: 30 mg/kg
The estimate for compound 3 lay 30-fold (1.48 log units) below the measured number, outside the stated range (above it).
By their numbers in this assay, from the lowest: compound 1; then compounds 2 and 3 (each within the scatter of the next).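

Butyl in place of hydrogen on this saturated chain carbon brings a 100-fold higher number from compound 1 to compound 3 (2.00 log units; beyond the scatter) in this assay. A longer chain at this position therefore does not keep the low dose of compound 1, and a change on the saturated chain can shift the read-out as far as the earlier change on the aromatic carbon did. No measured evidence explains this rise. Still open, on these data alone, is whether adding only methyl or ethyl here preserves the low dose, and where along the chain the rise begins. An amine or a carboxylic acid at this carbon is also untested among the compounds shown.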